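A few compounds are considered here, and "the series" means these few. Any claim that something is new, unique, unknown or untested is made for them only; others in the source may bear on it.

Measured so far:
Compound 1 `CCc1c(C(=O)OC)[nH]c2cc(OC)ccc12`: > 100000 nM (a limit)
Compound 2 `COC(=O)c1[nH]c2cc(OC)ccc2c1CC(C)C`: 16600 nM

Among the measured compounds shown here, in a functional assay on CCRF-CEM cells (Homo sapiens) for antiproliferative activity, read by MTT assay, with a stated time of 48 h (on this read-out lower numbers stand for an effect already at smaller amounts and higher numbers for an effect only at larger amounts of compound), compound 2 gives 16600 nM, the only actual number available so far. Compound 1 gives > 100000 nM, which is a limit of the assay and not a number.

Compound 3 `COC(=O)c1[nH]c2cc(OC)ccc2c1Cc1ccccc1` keeps the shared core of compound 2 and carries phenyl in place of isopropyl on a saturated chain carbon bound to an aromatic carbon. The same difference, cut one bond further out, reads isobutyl to benzyl.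

For the measured compounds named here, only one measured step bears on this change, and it sits at the same place: an at least 6.0-fold lower number from compound 1 to compound 2 (0.77 log units; beyond the scatter). Its size is open-ended, as it rests on (the limit of > 100000 nM in this assay, at which 1 of the 2 values shown sits). A single step sets no pattern, so in this assay only a small shift towards a lower number is expected, probably not beyond the scatter, going by the step to compound 2 of an at least 6.0-fold lower number from compound 1 to compound 2 (0.77 log units; beyond the scatter). The estimated change is a 1.8-fold lower number from compound 2 to compound 3 (0.27 log units; within the scatter). For compound 3 the expected value is 9000 nM, with an estimated range of 2500 nM to 35000 nM.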

Compound 3, half-maximal effective concentration: 8700 nM
For compound 3 the middle estimate is 1.0-fold (0.01 log units) above the measured one; the measured number falls inside the stated range.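

In this assay, phenyl in place of isopropyl on a saturated chain carbon bound to an aromatic carbon gives a 1.9-fold lower number from compound 2 to compound 3 (0.28 log units; within the scatter), so compound 2 and compound 3 cannot be told apart on this read-out, and the isobutyl and benzyl forms of this position serve about equally. Set against compound 1, phenyl in place of methyl gives an at least 11-fold lower number from compound 1 to compound 3 (1.06 log units; beyond the scatter), which shows that an aromatic ring at this place, like the branched chain of compound 2, stands clearly apart from compound 1. The true size of that step stays open, as the value of compound 1 is a limit and not a number: the limit of > 100000 nM in this assay, at which 1 of the 3 values shown sits.

The three compounds show only carbon-only groups at this position, so they leave open how an amine or a carboxylic acid on the chain would fare, and whether a longer chain, such as phenylethyl, would hold the number seen with benzyl. They also leave open how far the methyl ester, which all three share, contributes to the numbers, since it stays the same throughout.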